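A few compounds are considered here, and "the series" means these few. Any claim that something is new, unique, unknown or untested is made for them only; others in the source may bear on it.

Measured so far:

Compound 1, `C=Cc1nc2ccccc2n1C`: 2340 nM
Compound 2, `C=Cc1nc2ccccc2o1`: > 40000 nM
Compound 3, `C#Cc1nc2ccccc2n1C`: 8140 nM

In a functional assay on NCI-H522 cells (Homo sapiens) for cytotoxicity, with a stated time of 3 days (a lower number here means a stronger inhibitor, a higher number a weaker inhibitor), compound 1 gives 2340 nM, while compound 3 gives 8140 nM. The step between them, a 3.5-fold higher number from compound 1 to compound 3 (0.54 log units; beyond the scatter), is modest but beyond the scatter, and the structural change is ethynyl in place of vinyl on an aromatic carbon. The value of compound 2 in this assay is a limit of the assay, namely > 40000 nM, as the limit of > 40000 nM in this assay, at which 1 of the 3 values shown sits, shows. How the core of compound 2 differs from the core of compound 1 is not broken down here.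

Compound 4, `C#Cc1nc2ccccc2o1`, has not yet been measured. It differs from compound 2 by ethynyl in place of vinyl on an aromatic carbon. This is the same kind of change as that from compound 1 to compound 3, but the place differs: here it sits on a five-membered aromatic ring with 1 nitrogen and 1 oxygen, next to the ring nitrogen and next to the ring oxygen, whereas there it sat between two ring nitrogen atoms, next to the ring atom that bears a methyl group.

A step like a 3.5-fold higher number from compound 1 to compound 3 (0.54 log units; beyond the scatter) is expected here as well, which would carry compound 4 further past the limit. The expected step is a step that the limit leaves unreadable from compound 2 to compound 4. Compound 4 is therefore estimated at 120000 nM, between 40000 nM and 400000 nM, most likely reported only as a limit.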

Compound 4, half-maximal inhibitory concentration: 1260 nM
Compound 4: middle estimate off by 95-fold (1.98 log units), on the high side, outside the stated range (below it).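

In this assay, putting ethynyl in place of vinyl on the core of compound 2 gives an at least 31-fold lower number from compound 2 to compound 4 (1.50 log units; beyond the scatter), whereas on the other core the same change gives a 3.5-fold higher number from compound 1 to compound 3 (0.54 log units; beyond the scatter). The change therefore does not carry over from one core to the other as a fixed step, and here even its direction differs: the same change on two cores in this assay, a 3.5-fold higher number (0.54 log units; beyond the scatter) from compound 1 to compound 3 and an at least 31-fold lower number (1.50 log units; beyond the scatter) from compound 2 to compound 4, at least 110-fold (2.04 log units) apart, beyond the scatter of two such steps Compound 2 gives > 40000 nM, which is a limit of the assay and not a number, so the second step is known only as a bound, and these two pairs do not show why the direction turns.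

The compounds shown leave open how a nitrile or an ethyl group on the same aromatic carbon would read in this assay on either core. They also leave open whether the change on a third core would follow the pair of compound 1 and compound 3 or the pair of compound 2 and compound 4.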